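From Chloro to Difluoromethoxy on the Benzyl Tail

The source may report more compounds than this note shows. Statements on the series, on what has been measured and on what is new or still open speak of the compounds shown alone.

Compound 1 `CCOc1ccc(C(O)C2OC(=O)c3c(OC)cc(OC)cc32)cc1` gives > 10000 nM (a limit of the assay)
Compound 2 `CCCCOc1ccc(C(O)C2OC(=O)c3c(OC)cc(OC)cc32)cc1` gives 1800 nM
Compound 3 `COc1cc(OC)c2c(c1)C(C(O)c1ccc(OCc3ccc(Cl)cc3)cc1)OC2=O` gives 4320 nM

In a functional assay on RAW264.7 cells (Mus musculus) for inhibition, read by Griess assay, with stated times of 1 h and 24 h (on this read-out higher numbers stand for weaker inhibition and lower numbers for stronger inhibition), compound 3 gives 4320 nM and holds the higher of the two true numbers. The measured step to it is a 2.4-fold higher number from compound 2 to compound 3 (0.38 log units; beyond the scatter). Compound 1 stands at > 10000 nM, which is a limit and not a number.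

Compound 4 `COc1cc(OC)c2c(c1)C(C(O)c1ccc(OCc3ccc(OC(F)F)cc3)cc1)OC2=O` differs from compound 3 in one group: difluoromethoxy in place of chloro on an aromatic carbon. This puts difluoromethoxy in place of chloro on an aromatic carbon, para to a large group.

Going by the values given here, no measured step touches that chloro. The nearest steps change the same ether chain: an at least 5.5-fold lower number from compound 1 to compound 2 (0.74 log units; beyond the scatter) and an at least 2.3-fold lower number from compound 1 to compound 3 (0.36 log units; beyond the scatter). Both are only modest or open-ended, and neither gives a direction for this swap. In this assay no step beyond the scatter is therefore expected, and the estimate means a 1.2-fold lower number from compound 3 to compound 4 (0.09 log units; within the scatter). Compound 4 is expected at 3500 nM, with an estimated range from 1300 nM to 9500 nM.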

Compound 4, half-maximal inhibitory concentration: 5030 nM
Beside the measured number, compound 4's estimate is 1.4-fold (0.16 log units) below it; measured number inside the range.
By their numbers in this assay, from the lowest: compound 2; then compounds 3 and 4 (each within the scatter of the next). At a limit, above all of these: compound 1.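

In this assay, difluoromethoxy in place of chloro on an aromatic carbon, para to a large group, gives a 1.2-fold higher number from compound 3 to compound 4 (0.07 log units; within the scatter). A group of 4 heavy atoms, with 1 hydrogen-bond acceptor, thus stands at this place in place of a single chlorine without a step that can be told from the scatter. Going by these compounds alone, the second group at this place also leaves the gap to compound 2 in place, with a 2.8-fold higher number from compound 2 to compound 4 (0.45 log units; beyond the scatter) and a sign that matches the one compound 3 showed. Compound 1 stands at a limit and not at a number: the limit of > 10000 nM in this assay, at which 1 of the 4 values shown sits. The step from that limit is an at least 1.9-fold lower number from compound 1 to compound 4 (0.29 log units; that floor lies within the scatter), and it can be read only as a floor.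

Only chloro and difluoromethoxy are shown at this place. As far as these compounds go, whether an amine or a carboxylic acid there, or a longer chain in place of the benzyl tail, would give a step beyond the scatter stays open.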